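Carbonyl substituent swap on the thiazole-amide series, compound 4

This account rests on a few compounds, and the source may have more. Where it says the series, first, only, none or still open, it means among the compounds named here.

Measured so far:
- compound 1 `CCOC(=O)c1sc(-c2cccc(NC(=O)c3ccc(C(F)(F)F)cn3)c2)nc1Nc1ccc(N2CCN(C)CC2)cc1`: "not determined" (no result reported) in a functional assay on Raji cells (Homo sapiens) for antiproliferative activity, read by CCK-8 assay, with a stated time of 72 h; on this read-out lower numbers stand for stronger inhibition and higher numbers for weaker inhibition
- compound 2 `CN1CCN(c2ccc(Nc3nc(-c4cccc(NC(=O)c5ccccc5)c4)sc3C(N)=O)cc2)CC1`: 6360 nM in this assay
- compound 3 `CN1CCN(c2ccc(Nc3nc(-c4cccc(NC(=O)c5cccc(F)c5)c4)sc3C(N)=O)cc2)CC1`: "not determined" (no result reported) in this assay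

Compound 3 stands without a number: the only figure in the set is that of compound 2, which in this assay gives 6360 nM, while compound 1 gives "not determined" (no result reported) and compound 3 gives "not determined" (no result reported), neither of which is a reported result. Going by the values given here, nothing links compound 2 to compound 3 by a counted step, so their pair tells only that one has a value and the other none.

Compound 4 `CN1CCN(c2ccc(Nc3nc(-c4cccc(NC(=O)c5ccc(C(F)(F)F)cn5)c4)sc3C(N)=O)cc2)CC1` is the next entry. It differs from compound 3 by 5-(trifluoromethyl)pyridin-2-yl in place of 3-fluorophenyl on a carbonyl carbon whose other neighbours are an amide-type nitrogen. Among the compounds with values here, no step between measured compounds is available to size this change in this assay. With compound 2 as the only anchor in this assay at 6360 nM, and the shared core otherwise unchanged, the expectation is a value of the same order, with no direction claimed beyond the scatter. Compound 4 is estimated at 3500 nM, with a range from 900 nM to 14000 nM.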

Compound 4, half-maximal inhibitory concentration: 24500 nM
The estimate for compound 4 lay 7.0-fold (0.85 log units) below the measured number; the whole stated range lies below it.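

In this assay, going by these compounds alone, this is the first sized change on this carbonyl carbon: 5-(trifluoromethyl)pyridin-2-yl in place of phenyl gives a 3.9-fold higher number from compound 2 to compound 4 (0.59 log units; beyond the scatter), so inhibition is weaker by a modest step beyond the scatter. The group on this carbonyl carbon therefore affects the read-out, at least for this one pair with the rest of the structure held constant. No measured evidence accounts for the shift.

The entering group brings a ring nitrogen and a trifluoromethyl together, so this single step cannot assign the higher number to either, and a plain pyridin-2-yl would be needed to separate them. Also open, going by these compounds, is how far the trend extends, for example to an amine or a longer alkyl chain on the same carbonyl carbon.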